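A Moved Nitro Group on a Series at the Limit

A few compounds are considered here, and "the series" means these few. Any claim that something is new, unique, unknown or untested is made for them only; others in the source may bear on it.

Of the compounds shown here, three of one series have been tested in a functional assay on CCRF-CEM cells (Homo sapiens) for cytotoxicity, in the absence of a further agent; on this read-out higher numbers stand for weaker inhibition and lower numbers for stronger inhibition. Compound 1 `COC(=O)c1ccc(CN(CCCc2c(N)nc(N)nc2O)c2cc(F)cc(F)c2[N+](=O)[O-])cc1` gives > 100000 nM in this assay, which is a limit of the assay and not a number. Compound 2 `Nc1nc(N)c(CCCN(Cc2ccc(NC(CCC(=O)O)C(=O)O)cc2)c2cc(F)cc(F)c2[N+](=O)[O-])c(O)n1` likewise gives > 100000 nM, again a limit. Compound 3 `Nc1nc(N)c(CCCNc2cc(F)ccc2[N+](=O)[O-])c(O)n1` gives > 100000 nM, also a limit. Going by the values given here, the only step between neighbours, with (1,3-dicarboxypropyl)amino in place of methoxycarbonyl on an aromatic carbon, is a step that the two limits leave unreadable from compound 1 to compound 2 because of the limit of > 100000 nM in this assay, at which 3 of the 3 values shown sit. Compound 2 thus stands at the limit of this assay, as do the other two compounds.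

Compound 4 `Nc1nc(N)c(CCCN(Cc2ccc(NC(CCC(=O)O)C(=O)O)cc2)c2ccc([N+](=O)[O-])c(F)c2F)c(O)n1` differs from compound 2 by 2,3-difluoro-4-nitrophenyl in place of 3,5-difluoro-2-nitrophenyl on an amine nitrogen. Among the compounds with values here, no measured step bears directly on this change, and the single measured step that the two limits leave unreadable from compound 1 to compound 2 is of unreadable size, with every value sitting at the limit. One therefore expects no readable movement in this assay, and the estimated step that the limit leaves unreadable from compound 2 to compound 4 for compound 4 reflects that. For compound 4 the estimate is 150000 nM, in the range 40000 nM to 1000000 nM, most probably again only a limit.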

Compound 4, half-maximal inhibitory concentration: > 100000 nM
Compound 4: only a limit was reported (the forecaster's own chance of this, stated with the estimate: 85%); the middle value is on the limit's open side.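

In this assay compound 4 gives > 100000 nM, a limit of the assay and not a number. No step can be read between compound 2 and compound 4, because both sit at the same limit: the limit of > 100000 nM in this assay, at which 4 of the 4 values shown sit.

The compounds shown leave open how 2,3-difluoro-4-nitrophenyl and 3,5-difluoro-2-nitrophenyl compare on any readable value.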